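The source may report more compounds than this note shows. Statements on the series, on what has been measured and on what is new or still open speak of the compounds shown alone.

Compound 1 `COc1nc2ccccc2cc1/C=C/c1noc(-c2ccccc2)n1`: in an ADME assay on HepG2 cells (Homo sapiens) for cytotoxicity, read by sulforhodamine B assay, with a stated time of 48 h (on this read-out lower numbers stand for higher toxicity in this test and higher numbers for lower toxicity in this test), compound 1 gives > 240000 nM, which is a limit of the assay and not a number.
Compound 2 `COc1ccc(-c2nc(/C=C/c3cc4ccccc4nc3OC)no2)cc1`: in this assay compound 2 gives > 220000 nM, again a limit.
Compound 3 `COc1nc2ccccc2cc1/C=C/c1noc(-c2ccccc2Br)n1`: in this assay compound 3 gives > 195000 nM, also a limit.

Since every measured value is a limit, compound 3 stands at a limit like the two others, and the steps a step that the two limits leave unreadable from compound 1 to compound 2, a step that the two limits leave unreadable from compound 1 to compound 3 and a step that the two limits leave unreadable from compound 2 to compound 3 have no readable size. Compound 4 `COCc1nc(/C=C/c2cc3ccccc3nc2OC)no1` differs from compound 3 by methoxymethyl in place of 2-bromophenyl on an aromatic carbon. Among the measured compounds shown here, no measured step gives a readable size for such a change; the only evidence is that each compound sits at a limit (the limit of > 195000 nM in this assay, at which 1 of the 3 values shown sits, (the limit of > 220000 nM in this assay, at which 1 of the 3 values shown sits), (the limit of > 240000 nM in this assay, at which 1 of the 3 values shown sits)). Compound 4 is therefore expected to show no step beyond the scatter in this assay, estimated at 200000 nM with a range from 100000 nM to 300000 nM, meaning a step that the limit leaves unreadable from compound 3 to compound 4, and most likely again reported only as a limit.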

Compound 4, half-maximal cytotoxic concentration: > 270000 nM
Compound 4: a limit, no number (the forecaster's own chance of this, stated with the estimate: 85%); at least 1.3-fold (0.13 log units) between middle value and limit.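

Compound 4 stands at a limit, like compound 1, compound 2 and compound 3, and none of the steps to compound 4 can be read. The compounds shown leave open at what concentration any of them would be toxic in this assay.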